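The source may hold more compounds than are shown below. What is called first, only, known or untested is meant among the compounds shown, and "the series" means these compounds.

Measured so far in a functional assay on HeLa cells (Homo sapiens) for inhibition, read by cell counting, with a stated time of 96 h; a lower number here means a stronger inhibitor, a higher number a weaker inhibitor:
- compound 1 `CCN(CC)CN1C(=O)/C(=N/NC(=S)Nc2ccccc2)c2cc(Cl)ccc21`: 34000 nM
- compound 2 `CCN(CC)CN1C(=O)/C(=N/NC(=S)Nc2ccc(Cl)cc2)c2ccccc21`: 7600 nM
- compound 3 `CCN(CC)CN1C(=O)/C(=N/NC(=S)Nc2ccc(OC)cc2)c2cc(Cl)ccc21`: 9200 nM

Not yet measured:
- compound 4 `CCN(CC)CN1C(=O)/C(=N/NC(=S)Nc2ccc(Cl)cc2)c2cc(Cl)ccc21`

Compound 1 has the highest number of the three measured compounds, so it is the weakest inhibitor in this small set. The values of compound 2 and compound 3 lie within the usual scatter of each other, and both are clearly lower than that of compound 1.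

The step of interest runs from compound 1 to compound 4: chloro in place of hydrogen on an aromatic carbon. In words, this is chloro in place of hydrogen on an aromatic carbon, turning phenyl into 4-chlorophenyl.

Among the compounds with values here, only one measured step compares directly, with methoxy in place of hydrogen on an aromatic carbon: a 3.7-fold lower number from compound 1 to compound 3 (0.57 log units; beyond the scatter). It is modest, but beyond the scatter. Compound 2 also carries the 4-chlorophenyl group, though its core has no chloro, and it gives 7600 nM. It differs from compound 1 in more than one place, so it offers only indirect support.

A modest move to a lower number is therefore expected in this assay. The expected step is a 3.8-fold lower number from compound 1 to compound 4 (0.58 log units; beyond the scatter). Compound 4 is estimated at 9000 nM, with an expected range from 3000 nM to 25000 nM.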

Compound 4, half-maximal inhibitory concentration: > 125000 nM
Compound 4 was reported as a limit (the forecaster's own chance of this, stated with the estimate: 3%); middle value at least 13-fold (1.14 log units) away from the limit.
By their numbers in this assay, from the lowest: compounds 2 and 3 (each within the scatter of the next); then compound 1. At a limit, above all of these: compound 4.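

In this assay, chloro in place of hydrogen on the phenyl ring does not follow methoxy at this position: the change to 4-chlorophenyl gives an at least 3.6-fold higher number from compound 1 to compound 4 (0.56 log units; beyond the scatter), while exchanging methoxy for chloro at the same position on the shared core gives an at least 13-fold higher number from compound 3 to compound 4 (1.13 log units; beyond the scatter). The effect of this para chloro also cannot be read from the ring alone, since with the 4-chlorophenyl group held constant, chloro in place of hydrogen on an aromatic carbon of the core gives an at least 16-fold higher number from compound 2 to compound 4 (1.21 log units; beyond the scatter). Compound 4 is reported only as a limit, so all three steps give a minimum size and not a measured one: the limit of > 125000 nM in this assay, at which 1 of the 4 values shown sits.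

As far as these compounds go, whether the loss of inhibition is specific to chloro or extends to other small groups at this position remains open, and fluoro, methyl or nitrile on the same core would help separate those readings. Also open, from the compounds shown here alone, is whether the same steps hold when the diethylamino group is replaced by a morpholine or a pyrrolidine.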